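Dropping an Aromatic Fluorine: Expected Lipophilicity of Compound 4

The source may hold more compounds than are shown below. What is called first, only, known or untested is meant among the compounds shown, and "the series" means these compounds.

Compound 2 `O=C(O)C[C@H](O)C[C@H](O)CCn1c(-c2ccc(F)cc2)nc(C(=O)NCc2ccccc2F)c1C1CC1` gives the lowest of the three numbers in a physicochemical assay for lipophilicity, using the shake flask method, at pH 7.4 (on this read-out higher numbers stand for higher lipophilicity and lower numbers for lower lipophilicity), namely 0.08. Compound 3 `O=C(O)C[C@H](O)C[C@H](O)CCn1c(-c2ccc(F)cc2)nc(C(=O)NCc2ccc(F)cc2)c1C1CC1` gives 0.17 and compound 1 `Cc1ccc(CNC(=O)c2nn(-c3ccc(F)cc3)c(CC[C@@H](O)C[C@@H](O)CC(=O)O)c2C(C)C)cc1` gives 0.24; both sit within the scatter of compound 2, so the three cannot be ordered. The unmeasured compound 4 `O=C(O)C[C@H](O)C[C@H](O)CCn1c(-c2ccc(F)cc2)nc(C(=O)NCc2ccccc2)c1C1CC1` differs from compound 2 by hydrogen in place of fluoro on an aromatic carbon. For the measured compounds named here, the one measured step on this ring, a number 0.09 log units higher from compound 2 to compound 3 (within the scatter), moves the fluoro from one aromatic carbon to another rather than removing it, so no measured step matches the change exactly. Given that small step, the step of a number 0.13 log units lower from compound 2 to compound 4 (within the scatter) is expected to stay within the scatter, leaning slightly lower. Compound 4 is therefore estimated at -0.05, with a range from -0.35 to 0.25.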

Compound 4, distribution coefficient: 0.03
Compound 4: middle estimate off by 0.08 log units, on the low side; the measured number falls inside the stated range.
By their numbers in this assay, from the lowest: compounds 4, 2, 3 and 1 (each within the scatter of the next).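

Fluoro on this ring has now been replaced outright rather than moved, and in this assay the hydrogen gives only small steps (a number 0.05 log units lower from compound 2 to compound 4 (within the scatter); a number 0.14 log units lower from compound 3 to compound 4 (within the scatter)). With either the 2-fluorophenyl or the 4-fluorophenyl group, the compound stays within the scatter of compound 4, so fluoro at neither place makes a readable difference to this number.

As far as these compounds go, whether a trifluoromethyl, a methoxy or an amine on this ring would move the number beyond the scatter remains open. No measurement at hand offers a reason for these small steps.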